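Pyridyl for phenyl on the benzylic arm of the core

A few compounds are considered here, and "the series" means these few. Any claim that something is new, unique, unknown or untested is made for them only; others in the source may bear on it.

Compound 1 `COc1ccc(NC(=O)CN2CCN(c3nnc(Cc4ccccc4)c4ccccc34)CC2)cc1OC` gives the highest number of the three in a functional assay on HT-29 cells (Homo sapiens) for cytotoxicity, read by MTT assay, with a stated time of 72 h (on this read-out higher numbers stand for weaker inhibition and lower numbers for stronger inhibition), at 145000 nM. Compound 3 `Cc1ccccc1NC(=O)CN1CCN(c2nnc(Cc3ccccc3)c3ccccc23)CC1` sits nearest, with 113000 nM, and the step of a 1.3-fold lower number from compound 1 to compound 3 (0.11 log units; within the scatter) stays within the scatter. Compound 2 `O=C(CN1CCN(c2nnc(Cc3ccccc3)c3ccccc23)CC1)Nc1ccc(F)c(Cl)c1` lies furthest, at 13300 nM; the step of an 11-fold lower number from compound 1 to compound 2 (1.04 log units; beyond the scatter) is the one large move in the set, and an 8.5-fold higher number from compound 2 to compound 3 (0.93 log units; beyond the scatter) reverses most of it. Compound 4 `COc1ccc(NC(=O)CN2CCN(c3nnc(Cc4ccncc4)c4ccccc34)CC2)cc1OC` differs from compound 1 by pyridin-4-yl in place of phenyl on a saturated chain carbon bound to an aromatic carbon. Among the measured compounds shown here, none of the measured steps touches this position: all three swap the aryl group on the amide-type nitrogen, and the benzyl arm of the shared core is unchanged across the set. For the measured compounds named here, with no step of this kind available, compound 4 is expected to show a step of a 1.0-fold lower number from compound 1 to compound 4 (0.02 log units; within the scatter), none beyond the scatter. Compound 4 is therefore estimated at 140000 nM, with a range of 45000 nM to 400000 nM.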

Compound 4, half-maximal inhibitory concentration: 40100 nM
Beside the measured number, compound 4's estimate is 3.5-fold (0.54 log units) above it; measured number outside the range, below it.
By their numbers in this assay, from the lowest: compound 2; then compound 4; then compounds 3 and 1 (each within the scatter of the next).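

The benzylic arm of the shared core is not a silent position: in this assay, pyridin-4-yl in place of phenyl gives a 3.6-fold lower number from compound 1 to compound 4 (0.56 log units; beyond the scatter), with the amide-side aryl group left unchanged. Among the compounds shown here, the earlier steps changed only the aryl group on the amide-type nitrogen, so this is the first shift seen from the other end of the molecule. Nothing measured here accounts for the shift.

From the compounds shown here alone, it remains open whether the same change carries over to the 3-chloro-4-fluorophenyl group of compound 2. Also open, going by these compounds, is whether pyridin-3-yl, or a phenyl bearing an amine, would do the same at this place.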